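Ring in Place of Branched Chain on the Aromatic Oxygen

A few compounds are considered here, and "the series" means these few. Any claim that something is new, unique, unknown or untested is made for them only; others in the source may bear on it.

Compound 1 `CCCOc1cc(C(F)(F)F)ccc1CNC(=O)C(C)c1ccc(NS(C)(=O)=O)c(F)c1` and compound 2 `CC(C)CCOc1cc(C(F)(F)F)ccc1CNC(=O)C(C)c1ccc(NS(C)(=O)=O)c(F)c1` share one core and differ only in the group attached to an oxygen on an aromatic ring. In an assay on CHO cells for antagonist activity at transient receptor potential cation channel subfamily V member 1 (Homo sapiens), read by FLIPR (a lower number here means a stronger inhibitor, a higher number a weaker inhibitor), compound 1 gives 2 nM, while compound 2 gives 0.5 nM. Among the measured compounds shown here, the single step measured so far, a 4.0-fold lower number from compound 1 to compound 2 (0.60 log units; beyond the scatter), came from isopropyl in place of methyl two bonds along the chain from that oxygen. On the numbers shown, compound 2 stands as the lowest of the two, with compound 1 as its only neighbour.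

Compound 3 `CC(C(=O)NCc1ccc(C(F)(F)F)cc1OC1CCCCC1)c1ccc(NS(C)(=O)=O)c(F)c1` carries the next change: cyclohexyl in place of isopentyl on an oxygen on an aromatic ring. The group that leaves and the group that enters are close in size, as the counts show. For the measured compounds named here, the one measured step bears only loosely on this: it shows that lengthening the chain on this oxygen lowered the number, but it says nothing about a ring taking the place of a branched chain. A step no larger than the scatter is therefore expected, in either direction. For compound 3 in this assay the estimate is 0.6 nM, ranging from 0.2 nM to 2 nM, which would mean a 1.2-fold higher number from compound 2 to compound 3 (0.08 log units; within the scatter).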

Compound 3, inhibition constant: 0.7 nM
Compound 3: middle estimate off by 1.2-fold (0.07 log units), on the low side, within the range that was stated.
By their numbers in this assay, from the lowest: compounds 2 and 3 (each within the scatter of the next); then compound 1.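

In this assay, going from the open isopentyl chain to the closed cyclohexyl ring gives a 1.4-fold higher number from compound 2 to compound 3 (0.15 log units; within the scatter), so on this oxygen the ring and the branched chain cannot be told apart. Against the short straight chain, cyclohexyl in place of propyl gives a 2.9-fold lower number from compound 1 to compound 3 (0.46 log units; beyond the scatter), which shows that the drop first seen with isopentyl does not depend on an open, branched chain and is also found with a ring. Nothing shown bears on why the ring and the chain read alike.

The three groups on this oxygen are all built from carbon alone, which leaves open how a smaller ring such as cyclopentyl, a ring holding an oxygen such as tetrahydropyranyl, or a flat phenyl ring would read at this position. On these data alone, all three compounds also share one core, and whether cyclohexyl and isopentyl would still read alike on a different core stays open.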